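This account rests on a few compounds, and the source may have more. Where it says the series, first, only, none or still open, it means among the compounds named here.

Compound 1 `COc1n[nH]c2ncc(-c3cn(-c4c(F)ccc(NS(=O)(=O)c5cccc(Cl)c5)c4F)nn3)cc12` is a kinase inhibitor tested in an assay on Sf9 cells for inhibition of mitogen-activated protein kinase kinase kinase 20 (Homo sapiens), read by ADP-Glo, with a stated time of 30 min (a higher number here means a weaker inhibitor, a lower number a stronger inhibitor), where compound 1 gives 1.9 nM. Going by the values given here, its closest relative, compound 2 `COc1n[nH]c2ncc(-c3cn(-c4cc(NS(=O)(=O)c5cccc(Cl)c5)ccc4F)nn3)cc12`, gives 5.7 nM in the same test, and the single step between them, a 3.0-fold higher number from compound 1 to compound 2 (0.48 log units; beyond the scatter), is the only measured change in this small set. Compound 1 therefore stands as the lowest of the two numbers shown.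

Compound 3 `COc1n[nH]c2ncc(-c3cn(-c4c(F)ccc(NS(=O)(=O)c5cccc6ccccc56)c4F)nn3)cc12` is not yet measured. It differs from compound 1 in one place, (naphthalen-1-yl in place of 3-chlorophenyl on a sulfonyl sulfur), so a larger two-ring aromatic group now sits on the sulfonyl sulfur where a single chlorinated ring stood before. Among the compounds with values here, no measured step touches this part of the molecule; the step from compound 1 to compound 2 concerns a fluoro on a different ring and gives no guidance here. The expectation must rest on the good potency of compound 1 alone, and the estimated step of a 2.1-fold higher number from compound 1 to compound 3 (0.32 log units; beyond the scatter) is therefore uncertain. Compound 3 is expected to give about 4 nM, plausibly between 1 nM and 20 nM.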

Compound 3, half-maximal inhibitory concentration: 4.2 nM
Estimate against measurement, compound 3: 1.1-fold (0.02 log units) below; the range from low to high includes it.
By their numbers in this assay, from the lowest: compound 1; then compounds 3 and 2 (each within the scatter of the next).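

Going by these compounds alone, no earlier step touched the group on the sulfonyl sulfur, and here, in this assay, the change to naphthalen-1-yl gives a 2.2-fold higher number from compound 1 to compound 3 (0.34 log units; beyond the scatter). The step is modest: a group of 10 heavy atoms with two aromatic rings replaces one of 7 heavy atoms with a single ring, and compound 3 still gives 4.2 nM, so this position tolerates a larger aromatic group with no chlorine. No measurement is available that would explain the size of this step.

From the compounds shown here alone, the change adds a second ring and removes the chlorine in one move, so the effect of each alone remains unknown. Also open, going by these compounds, is how a plain phenyl, a naphthalen-2-yl, a saturated cyclohexyl or a ring carrying an amine would behave on the same sulfonyl sulfur.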